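The source may report more compounds than this note shows. Statements on the series, on what has been measured and on what is new or still open speak of the compounds shown alone.

Compound 1 `COc1ccc(/C=C2\S/C(=N\c3csc(-c4ccc(Cl)cc4)c3)NC2=O)cc1`: in a functional assay on MCF7 cells (Homo sapiens) for cytotoxicity, read by MTT assay, with a stated time of 72 h (on this read-out lower numbers stand for stronger inhibition and higher numbers for weaker inhibition), compound 1 gives 1000 nM.
Compound 2 `O=C1N/C(=N/c2csc(-c3ccc(Cl)cc3)c2)S/C1=C\c1ccc(O)cc1`: in this assay compound 2 gives only a limit, > 50000 nM.

Compound 2 thus stands at the limit of > 50000 nM in this assay, at which 1 of the 2 values shown sits, so no exact number is known for it. Compound 3 `CCCCCC/C=C1\S/C(=N\c2csc(-c3ccc(Cl)cc3)c2)NC1=O` differs from compound 2 by hexyl in place of 4-hydroxyphenyl on a double-bonded chain carbon bound to a double-bonded ring carbon. Among the compounds with values here, the only measured step, an at least 50-fold higher number from compound 1 to compound 2 (1.69 log units; beyond the scatter), concerns a change on an oxygen of the very ring that now leaves, so it offers little guidance for this step. For compound 3 the expected outcome in this assay is 15000 nM, within 3000 nM to 50000 nM, meaning an estimated at least 3.3-fold lower number from compound 2 to compound 3 (0.52 log units; beyond the scatter).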

Compound 3, half-maximal inhibitory concentration: > 50000 nM
Compound 3 ended at the assay's limit (the forecaster's own chance of this, stated with the estimate: 40%); middle value at least 3.3-fold (0.52 log units) from the limit.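

Hexyl in place of 4-methoxyphenyl gives an at least 50-fold higher number from compound 1 to compound 3 (1.69 log units; beyond the scatter) in this assay. This shows that loss of a measurable value at this position is not confined to the 4-hydroxyphenyl of compound 2: among the three compounds, only the 4-methoxyphenyl group of compound 1 gives an exact number. Compound 2 and compound 3 both end at a limit, so the step between them cannot be read: the limit of > 50000 nM in this assay, at which 2 of the 3 values shown sit.

As far as these compounds go, whether a 4-ethoxyphenyl or 4-aminophenyl group here would give an exact number stays open. So does whether compound 2 and compound 3 truly differ.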